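Chain Extension and Monoamine Oxidase A Inhibition

The compounds below may be only part of what the source reports. "The series", "measured", "known", "first", "only" and "open" are said of these compounds alone.

Of the compounds shown here, three have been measured so far in an ADME assay on BTI cells for inhibition of Amine oxidase [flavin-containing] A (Homo sapiens), read by fluorescence and Amplex Red, with a stated time of 15 min, tested at 100 uM; on this read-out higher numbers stand for more inhibition at the one concentration tested (going by the name of the read-out) and lower numbers for less inhibition. Compound 1 `C#CCN(C)CCCOc1ccc2c(c1)OCCC2=O` gives 32.1% in this assay. Compound 2 `C#CCN(C)CCCCOc1ccc2c(c1)OCCC2=O` carries (methyl(propargyl)amino)methyl in place of methyl(propargyl)amino on a saturated chain carbon, three bonds along the chain from an oxygen on an aromatic ring relative to compound 1, and in this assay compound 2 gives 22.8%; the step is a number 9.3 percentage points lower from compound 1 to compound 2 (within the scatter). Compound 3 `C#CCN(C)CCCCCOc1ccc(C=O)c(OC)c1` rests on a different core; the difference between the cores of compound 1 and compound 3 is not broken down here. In this assay compound 3 gives 27.1%, which sits within the scatter of both compound 1 and compound 2.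

Compound 4 `C#CCN(C)CCCCCCOc1ccc(C=O)c(OC)c1` has not yet been measured. Relative to compound 3 it carries (methyl(propargyl)amino)methyl in place of methyl(propargyl)amino on a saturated chain carbon, five bonds along the chain from an oxygen on an aromatic ring. This is the same kind of change that separates compound 1 from compound 2, though the place differs: in the earlier pair the change sits three bonds along the chain from an oxygen on an aromatic ring, here five bonds along. Among the compounds with values here, in the one measured instance of this change, compound 1 to compound 2, the step fell within the scatter.

On that basis, and starting from the value of compound 3, compound 4 is expected to show a step of a number 7.1 percentage points lower from compound 3 to compound 4 (within the scatter) in this assay, a step of a size similar to the earlier one and itself within the usual scatter. Compound 4 is therefore estimated at 20%, with a likely range from 6% to 34%.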

Compound 4, a percentage reported as inhibition, at one concentration (the size of the read-out at that concentration, not a potency): 37.4%
The estimate for compound 4 lay 17.4 percentage points below the measured number; the measured number lies above the stated range.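

In this assay, replacing methyl(propargyl)amino with (methyl(propargyl)amino)methyl on the core of compound 3 gave a number 10.3 percentage points higher from compound 3 to compound 4 (beyond the scatter), a modest step that runs the opposite way to the one seen on the core of compound 1. The same change therefore did not carry over as a single, transferable step from one core to the other: the same change on two cores in this assay, a number 9.3 percentage points lower (within the scatter) from compound 1 to compound 2 and a number 10.3 percentage points higher (beyond the scatter) from compound 3 to compound 4, 19.6 percentage points apart, beyond the scatter of two such steps

This does not show that the core alone sets the outcome, since the two pairs also differ in place, with the change three bonds along the chain in one and five bonds along in the other, and each case rests on a single pair read at one concentration.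

The compounds shown leave open whether a longer chain on the core of compound 1 would follow the direction of compound 2 or that of compound 4, and whether a still longer chain on the core of compound 3 would extend the step to compound 4. They also leave open how a simple dimethylamine or a secondary amine in place of the methyl(propargyl)amino end would read on either core.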